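A few compounds are considered here, and "the series" means these few. Any claim that something is new, unique, unknown or untested is made for them only; others in the source may bear on it.

For the measured compounds named here, in an ADME assay on Vero cells (Chlorocebus sabaeus) for cytotoxicity, read by MTT assay, with a stated time of 72 h (on this read-out lower numbers stand for higher toxicity in this test and higher numbers for lower toxicity in this test), compound 2 `COc1c(N2CCN(C/C(C)=N/O)C(C)C2)c(F)cc2c(=O)c(C(=O)O)cn(C3CC3)c12` gives 177 ug/mL, the lower of the two numbers so far, while compound 1 `COc1c(N2CCN(C/C(C)=N/NC(N)=O)C(C)C2)c(F)cc2c(=O)c(C(=O)O)cn(C3CC3)c12` gives 500 ug/mL. Compound 3 `COc1c(N2CCN(CC/C(C)=N/Nc3ccccc3)C(C)C2)c(F)cc2c(=O)c(C(=O)O)cn(C3CC3)c12` carries this change from compound 2: a group of 11 heavy atoms (9 carbon, 2 nitrogen; one six-membered aromatic ring of carbon only) in place of a group of 4 heavy atoms (2 carbon, 1 nitrogen, 1 oxygen; no ring), on a saturated chain carbon bound to an amine nitrogen in a ring. Going by the values given here, only one measured step bears on it, the modest 2.8-fold lower number from compound 1 to compound 2 (0.45 log units; beyond the scatter), and that step brings in no aromatic ring, so it gives only weak guidance. A modest further fall in this assay is expected, of similar size to that step. The expected step is a 1.6-fold lower number from compound 2 to compound 3 (0.21 log units; within the scatter). Compound 3 is estimated at 110 ug/mL, with an expected range of 35 ug/mL to 350 ug/mL.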

Compound 3, half-maximal cytotoxic concentration: 62.5 ug/mL
Compound 3: middle estimate off by 1.8-fold (0.25 log units), on the high side; low and high end bracket the measured number.
By their numbers in this assay, from the lowest: compound 3; then compound 2; then compound 1.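

In this assay, the entering group with the six-membered aromatic ring of carbon only gives a lower number than either group without a ring (a 2.8-fold lower number from compound 2 to compound 3 (0.45 log units; beyond the scatter)) and (an 8.0-fold lower number from compound 1 to compound 3 (0.90 log units; beyond the scatter)). On a saturated chain carbon bound to an amine nitrogen in a ring, both changes lie beyond the scatter, so this position responds to the group it carries. No measurement shown accounts for this.

Whether the aromatic ring itself matters remains open, since a cyclohexyl group is not among the compounds shown. Going by these compounds, how an amine or a carboxylic acid on that ring would read is also open.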